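From benzylsulfanyl to propylsulfanyl: an expected loss

The compounds below may be only part of what the source reports. "The series", "measured", "known", "first", "only" and "open" are said of these compounds alone.

Of the compounds shown here, three have so far been measured in a functional assay on MCF7 cells (Homo sapiens) for antiproliferative activity, read by MTT assay, with a stated time of 72 h; on this read-out lower numbers stand for stronger inhibition and higher numbers for weaker inhibition. Compound 1 `CCCSc1nc(N/N=C/c2ccccc2Cl)c2nnn(Cc3ccccc3)c2n1` gives 13800 nM in this assay. For compound 2 `CCCSc1nc(N/N=C(\C)c2ccccc2O)c2nnn(Cc3ccccc3Cl)c2n1` this assay reports only a limit, > 64000 nM. Compound 3 `C/C(=N\Nc1nc(SCc2ccccc2)nc2c1nnn2Cc1ccccc1)c1ccccc1O` gives 950 nM, the lowest of the two plain numbers; the nearest, compound 1, stands above it by a gap that lies beyond the usual scatter.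

Compound 4 `CCCSc1nc(N/N=C(\C)c2ccccc2O)c2nnn(Cc3ccccc3)c2n1` differs from compound 3 in one place: ethyl in place of phenyl on a saturated chain carbon bound to a sulfur. Read one bond further out, benzylsulfanyl becomes propylsulfanyl. Among the measured compounds shown here, no measured pair isolates this change. Compound 1 and compound 2 both carry propylsulfanyl and both show weaker inhibition than compound 3, though each also differs in another part of the molecule, so the comparison is not clean.

The expected step is an 8.4-fold higher number from compound 3 to compound 4 (0.93 log units; beyond the scatter), towards weaker inhibition, well beyond the scatter. Compound 4 is therefore expected to give 8000 nM, within a range from 1500 nM to 40000 nM.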

Compound 4, half-maximal inhibitory concentration: 11000 nM
Beside the measured number, compound 4's estimate is 1.4-fold (0.14 log units) below it, and the stated range covers the measured number.
By their numbers in this assay, from the lowest: compound 3; then compounds 4 and 1 (each within the scatter of the next). At a limit, above all of these: compound 2.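

In this assay, the change from benzylsulfanyl to propylsulfanyl can now be read on its own, and it is a large loss (a 12-fold higher number from compound 3 to compound 4 (1.06 log units; beyond the scatter)). With propylsulfanyl in place, the change on a nitrogen on an aromatic ring stays within the scatter (a 1.3-fold lower number from compound 1 to compound 4 (0.10 log units; within the scatter)), while hydrogen in place of chloro on an aromatic carbon matters more (an at least 5.8-fold lower number from compound 2 to compound 4 (0.76 log units; beyond the scatter)). The starting value of that last step is a limit of the assay, not a plain number: the limit of > 64000 nM in this assay, at which 1 of the 4 values shown sits.

From the compounds shown here alone, only benzylsulfanyl and propylsulfanyl are compared on the sulfur, so it remains open how a longer chain such as hexyl, or a cyclohexylmethyl group, would read there. Also open, going by these compounds, is whether chloro on the benzyl group of compound 3 would bring a comparable loss.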